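A few compounds are considered here, and "the series" means these few. Any claim that something is new, unique, unknown or untested is made for them only; others in the source may bear on it.

Measured compounds:
- compound 1, `COc1cccc(/C=C/C(=O)c2ccc(OC)c3c2OC(C)(C)C=C3)c1`, in a functional assay on SK-OV-3 cells (Homo sapiens) for antiproliferative activity, read by MTT assay, with a stated time of 24 h (a lower number here means a stronger inhibitor, a higher number a weaker inhibitor), compound 1 gives 9360 nM
- compound 2, `COc1ccc(/C=C/C(=O)c2ccc(OC)c3c2OC(C)(C)C=C3)c(F)c1`, compound 2 gives 4880 nM
- compound 3, `COc1ccc(C(=O)/C=C/c2ccc(Br)cc2)c2c1C=CC(C)(C)O2`, compound 3 reaches only the assay limit of > 10000 nM

Compound 3 stands at the floor of the series: its value is a limit, not a number, as noted in the limit of > 10000 nM in this assay, at which 1 of the 3 values shown sits, so it is the weakest point that can be named here. The steps into compound 3 run an at least 1.0-fold higher number from compound 1 to compound 3 (0.02 log units; that floor lies within the scatter) and an at least 2.0-fold higher number from compound 2 to compound 3 (0.31 log units; beyond the scatter); within the measured compounds, compound 1 and compound 2 differ only by a 1.9-fold lower number from compound 1 to compound 2 (0.28 log units; within the scatter).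

Compound 4, `CCN(CC)c1ccc(/C=C/C(=O)c2ccc(OC)c3c2OC(C)(C)C=C3)cc1`, differs from compound 3 by diethylamino in place of bromo on an aromatic carbon. Within the data shown here, no measured pair exchanges bromo for an amino group, so the direction rests only on the observation that the methoxy-bearing aryl rings of compound 1 and compound 2 sit at numbers, while compound 3 sits at the limit. A step of that order is expected, with an at least 1.6-fold lower number from compound 3 to compound 4 (0.22 log units; that floor lies within the scatter) as the estimated change. Compound 4 is thus expected near 6000 nM, within 1500 nM to 12000 nM.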

Compound 4, half-maximal inhibitory concentration: 610 nM
Compound 4: middle estimate off by 9.8-fold (0.99 log units), on the high side; measured number below the stated range.
By their numbers in this assay, from the lowest: compound 4; then compounds 2 and 1 (each within the scatter of the next). At a limit, above all of these: compound 3.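

At this aromatic carbon, para to a large group, diethylamino in place of bromo gives an at least 16-fold lower number from compound 3 to compound 4 (1.21 log units; beyond the scatter) in this assay. Among these compounds, none of the earlier steps between aryl groups at this end of the chain is large, so this is the first sign that the substituent here can shift the antiproliferative read-out strongly. Compound 3 carries a limit and not a number, so the printed size of the step is only a floor: the limit of > 10000 nM in this assay, at which 1 of the 4 values shown sits.

Among the compounds shown here, the single exchange does not separate the contribution of the nitrogen from that of its two ethyl chains. From the compounds shown here alone, whether a dimethylamino group, a primary amine or a morpholine on the same aromatic carbon would hold a number in the range of compound 4 remains open.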